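Swapping the sulfonyl aryl group of compound 2

This account rests on a few compounds, and the source may have more. Where it says the series, first, only, none or still open, it means among the compounds named here.

Compound 1 `COc1ccc(-c2[nH]c3cc(OC)cc(OC)c3c(=O)c2I)cc1` and compound 2 `COc1ccc(-c2cc(=O)c3c(OC)cc(OC)cc3n2S(=O)(=O)c2cccc([N+](=O)[O-])c2)cc1` share a core and were both tested in a functional assay on HepG2 cells (Homo sapiens) for antiproliferative activity, with a stated time of 72 h; a higher number here means that more compound is needed for the effect, a lower number that less compound is needed. For compound 1 the result is only a limit, > 86200 nM. For compound 2 the result is also only a limit, > 39600 nM. Compound 2 therefore sits at the limit of > 39600 nM in this assay, at which 1 of the 2 values shown sits, with no number of its own. Compound 3 `COc1ccc(-c2cc(=O)c3c(OC)cc(OC)cc3n2S(=O)(=O)c2ccc(Cl)cc2)cc1` differs from compound 2 by 4-chlorophenyl in place of 3-nitrophenyl on a sulfonyl sulfur. Within the data shown here, no measured step between two compounds is known here, so no size of change is established. The expected step in this assay is a step that the limit leaves unreadable from compound 2 to compound 3, none beyond the scatter. Compound 3 is estimated at 40000 nM, with a range from 10000 nM to 100000 nM.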

Compound 3, half-maximal effective concentration: > 34400 nM
Compound 3 ended at the assay's limit; the forecaster's own chance of this, stated with the estimate: 70%; the middle value lies beyond the limit too.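

Compound 2 and compound 3 both end at a limit in this assay, and the step between them cannot be read. The compounds shown leave open how 4-chlorophenyl and 3-nitrophenyl on the sulfonyl sulfur compare in actual potency.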